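Solubility notes: saturated link in place of the cyanoethenyl

This account rests on a few compounds, and the source may have more. Where it says the series, first, only, none or still open, it means among the compounds named here.

Measured so far in a physicochemical assay for solubility, with a stated time of 4 h, at pH 7.4; on this read-out lower numbers stand for lower solubility and higher numbers for higher solubility:
compound 1, `COC(=O)c1cc(N)c(Nc2ccc(C#N)cc2)cc1Oc1c(C)cc(/C=C/C#N)cc1C`, gives 1.3 ug/mL
compound 2, `Cc1cc(CCC#N)cc(C)c1Oc1cc(Nc2ccc(C#N)cc2)c(N)cc1C(N)=O`, gives 0.06 ug/mL
compound 3, `Cc1cc(/C=C/C#N)cc(C)c1Oc1cc(Nc2ccc(C#N)cc2)c(N)cc1CO`, gives 3.23 ug/mL

Compound 3 stands highest of the three; compound 1 is nearest and compound 2 furthest below it, both beyond the scatter. Among the measured compounds shown here, the only single-point step measured so far is a 2.5-fold higher number from compound 1 to compound 3 (0.40 log units; beyond the scatter), which concerns the group on the core and not the side chain.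

Compound 4, `Cc1cc(CCC#N)cc(C)c1Oc1cc(Nc2ccc(C#N)cc2)c(N)cc1CO`, differs from compound 3 as follows: 2-cyanoethyl in place of 2-cyanoethenyl on an aromatic carbon. For the measured compounds named here, no measured step isolates this change. Compound 2 carries the 2-cyanoethyl and gives the lowest number, while compound 1 carries the 2-cyanoethenyl and sits higher, but these two compounds also differ at a second place, so their values alone cannot be read as the effect of the side chain.

Going by the values given here, with no direct precedent, a small downward step is expected, a 1.8-fold lower number from compound 3 to compound 4 (0.25 log units; within the scatter), wide in range. Compound 4 is therefore estimated at 1.8 ug/mL, between 0.4 ug/mL and 7 ug/mL.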

Compound 4, solubility: 18.8 ug/mL
Compound 4: the middle estimate sits 10-fold (1.02 log units) below what was measured; the whole stated range lies below it.
By their numbers in this assay, from the lowest: compound 2; then compound 1; then compound 3; then compound 4.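

In this assay, among the compounds shown here, 2-cyanoethyl in place of 2-cyanoethenyl gives a 5.8-fold higher number from compound 3 to compound 4 (0.76 log units; beyond the scatter) and so isolates the side chain for the first time: at this position, para to a large group, the saturated link goes with the higher number. With the 2-cyanoethyl held fixed, hydroxymethyl in place of carbamoyl gives a 310-fold higher number from compound 2 to compound 4 (2.50 log units; beyond the scatter) and shows that the low number of compound 2 goes with the carbamoyl, not with the saturated link. No measured evidence bears on the origin of either step.

From the compounds shown here alone, whether the side-chain step keeps its direction and size with methoxycarbonyl or carbamoyl on the core remains open. Also open, going by these compounds, is how the number moves with a longer chain ending in nitrile, or with an amine in place of the nitrile.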